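This account rests on a few compounds, and the source may have more. Where it says the series, first, only, none or still open, it means among the compounds named here.

Compounds measured in an ADME assay on 184B5 cells (Homo sapiens) for cytotoxicity, read by sulforhodamine B assay, with a stated time of 48 h; a lower number here means a stronger inhibitor of growth, a higher number a weaker inhibitor of growth:
compound 1, `CN(C)CN1C(=O)C(=O)c2c(Br)cccc21`: 77900 nM
compound 2, `O=C1C(=O)N(CN2CCCCC2)c2cccc(Br)c21`: 85200 nM

On the numbers shown, compound 2 sits at the upper end of the two, with compound 1 nearest; the step of a 1.1-fold higher number from compound 1 to compound 2 (0.04 log units; within the scatter) lies within the scatter, so the two compounds are not separated by this assay. For the measured compounds named here, that step exchanges the piperidin-1-yl for the dimethylamino on the saturated chain carbon bound to the amide-type nitrogen in the ring, and is the only measured step.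

Compound 3, `O=C1C(=O)N(CN2CCCCC2)c2cccc(Cl)c21`, differs from compound 2 by chloro in place of bromo on an aromatic carbon. Going by the values given here, no measured step touches a group on the aromatic carbon, so nothing in the data bears directly on this exchange; the one step known, from compound 1 to compound 2, concerns another site and was within the scatter. With no contrary indication, the expected step of a 1.1-fold higher number from compound 2 to compound 3 (0.02 log units; within the scatter) is taken to be none beyond the scatter. Compound 3 is therefore expected at 90000 nM in this assay, with a range from 45000 nM to 180000 nM.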

Compound 3, concentration for 50% growth inhibition: 93700 nM
Compound 3: the middle estimate sits 1.0-fold (0.02 log units) below what was measured; the measured number falls inside the stated range.
By their numbers in this assay, from the lowest: compounds 1, 2 and 3 (each within the scatter of the next).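

In this assay the exchange of bromo for chloro on the aromatic carbon gives a 1.1-fold higher number from compound 2 to compound 3 (0.04 log units; within the scatter) and so does not separate the two halogens at this site, at least with piperidin-1-yl on the chain. For the compounds shown here, this is the first measured step at the aromatic carbon; the earlier pair differed only at the chain, where the step was a 1.1-fold higher number from compound 1 to compound 2 (0.04 log units; within the scatter) and also within the scatter, so each of the two sites has now been exchanged once without a step beyond the scatter. No measured information on the series offers an explanation for this result.

Left open is whether a group of another kind on this aromatic carbon, such as methoxy, nitrile or a primary amine, or its replacement by plain hydrogen, would give a step beyond the scatter. Also open, going by these compounds, is whether chloro and bromo stay inseparable with dimethylamino on the chain, and whether a morpholine or a longer chain between the ring nitrogen and the amine would do anything that piperidin-1-yl did not.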